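The compounds below may be only part of what the source reports. "The series", "measured", "known", "first", "only" and "open" are said of these compounds alone.

- compound 1 `NC1=NC2(CCSCC2)N(OCCCOc2ccc(Cl)c(Cl)c2)C(N)=N1` gives 1 nM
- compound 2 `Cc1cc(C)cc(OCCCON2C(N)=NC(N)=NC23CCOCC3)c1` gives 190 nM
- compound 3 `NC1=NC2(CCOCC2)N(OCCCOc2cccc(Br)c2)C(N)=N1` gives 40 nM

In a functional assay on HCT-116 cells (Homo sapiens) for antiproliferative activity, read by MTT assay, with a stated time of 72 h (on this read-out lower numbers stand for stronger inhibition and higher numbers for weaker inhibition), compound 1 holds the lowest number of the three, with compound 3 and compound 2 both higher. Compound 4 `NC1=NC2(CCSCC2)N(OCCCOc2ccccc2Cl)C(N)=N1` differs from compound 1 in one group (2-chlorophenyl in place of 3,4-dichlorophenyl on an oxygen on a saturated carbon), with 2-chlorophenyl in place of 3,4-dichlorophenyl on an oxygen on a saturated carbon. Going by the values given here, only one measured step bears on this change, a swap at that same place (a 4.8-fold lower number from compound 2 to compound 3 (0.68 log units; beyond the scatter)). It shows that this group alone can move the number beyond the scatter, but it involves other groups, and the core of compound 2 and compound 3 differs from the core of compound 1. Among the compounds with values here, no measured compound carries 2-chlorophenyl, so the size of the step is uncertain. A higher number is expected, since compound 1 (1 nM) already stands lowest. The expected change is sizeable (a 15-fold higher number from compound 1 to compound 4 (1.18 log units; beyond the scatter)). For compound 4 the estimate is 15 nM in this assay, with an expected range from 3 nM to 80 nM for repeated measurements.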

Compound 4, half-maximal inhibitory concentration: 1 nM
The estimate for compound 4 lay 15-fold (1.18 log units) above the measured number; the measured number lies below the stated range.
By their numbers in this assay, from the lowest: compounds 1 and 4 (each within the scatter of the next); then compound 3; then compound 2.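

In this assay, replacing 3,4-dichlorophenyl with 2-chlorophenyl on an oxygen on a saturated carbon gives no change at the digits printed from compound 1 to compound 4 (within the scatter) on the core of compound 1. The earlier step at this place, a 4.8-fold lower number from compound 2 to compound 3 (0.68 log units; beyond the scatter), showed that a swap of this group can move the number, but it involved other groups on a different core; this pair shows that a change in the chlorine pattern, including the loss of one chlorine, need not move it. Nothing given here explains why the number holds.

From the compounds shown here alone, whether a plain phenyl with no chlorine, or a phenyl carrying an amine or a carboxylic acid, would also hold the number remains open. So does whether the same swap would leave the number unchanged on the core of compound 3.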